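Phenylsulfonyl in Place of Benzyl: Expected Partial Recovery

A few compounds are considered here, and "the series" means these few. Any claim that something is new, unique, unknown or untested is made for them only; others in the source may bear on it.

Compound 1 `COc1ccc(S(=O)(=O)N2CCc3cccc(NC(=O)c4ccc(C#N)cc4)c32)cc1` and compound 2 `COc1ccc(S(=O)(=O)N2CCc3cc(Br)cc(NC(=O)c4ccco4)c32)cc1` each carry an acyl group on a nitrogen on an aromatic ring; in a functional assay on MKN-45 cells (Homo sapiens) for cytotoxicity (a higher number here means a weaker inhibitor, a lower number a stronger inhibitor), compound 1 gives 89 nM and compound 2 gives 78 nM. Compound 3 `COc1ccc(S(=O)(=O)N2CCc3cccc(NCc4ccccc4)c32)cc1` reaches only a limit in this assay, > 10000 nM. Among the measured compounds shown here, the one measured step that bears on the present change is an at least 110-fold higher number from compound 1 to compound 3 (2.05 log units; beyond the scatter). Compound 4 `COc1ccc(S(=O)(=O)N2CCc3cccc(NS(=O)(=O)c4ccccc4)c32)cc1` differs from compound 3 by phenylsulfonyl in place of benzyl on a nitrogen on an aromatic ring. Because the step of an at least 110-fold higher number from compound 1 to compound 3 (2.05 log units; beyond the scatter) accompanied the exchange of an acyl group for benzyl, and phenylsulfonyl restores two hydrogen-bond acceptors where benzyl had none, compound 4 is expected to recover part of that loss, an at least 8.3-fold lower number from compound 3 to compound 4 (0.92 log units; beyond the scatter). For the measured compounds named here, no measured compound tests a sulfonyl against a carbonyl, so the recovery is expected to be incomplete. Compound 4 is estimated at 1200 nM, between 150 nM and 10000 nM.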

Compound 4, half-maximal inhibitory concentration: 562 nM
For compound 4 the middle estimate is 2.1-fold (0.33 log units) above the measured one, and the stated range covers the measured number.
By their numbers in this assay, from the lowest: compounds 2 and 1 (each within the scatter of the next); then compound 4. At a limit, above all of these: compound 3.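

Phenylsulfonyl in place of benzyl gives an at least 17-fold lower number from compound 3 to compound 4 (1.25 log units; beyond the scatter) in this assay and shows that this nitrogen tolerates a sulfonyl as well as a carbonyl link. Against the acyl group of compound 1 the same position gives a 6.3-fold higher number from compound 1 to compound 4 (0.80 log units; beyond the scatter) and so shows that the recovery is only partial. Compound 3 stands at a limit, so the first step gives only a minimum size: the limit of > 10000 nM in this assay, at which 1 of the 4 values shown sits.

On these data alone, it remains open whether a methylsulfonyl group or a urea on this nitrogen would do better, and whether a (4-cyanophenyl)sulfonyl group would close the remaining gap.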